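Half-life of an amidine ester amide after changing the nitrogen substituents

A few compounds are considered here, and "the series" means these few. Any claim that something is new, unique, unknown or untested is made for them only; others in the source may bear on it.

Compound 3 `CCN(CC(=O)O)C(=O)/C(C)=C/c1ccc(C(=O)Oc2ccc(C(=N)N)cc2)cc1` is one of three amidine esters measured in an in vitro ADME assay on the whole organism (small intestine) for pharmacokinetics, with Rattus norvegicus as the target; a lower number here means that the compound disappears faster, a higher number that the compound lasts longer. In this assay compound 3 gives > 1 h, which is a limit of the assay and not a number. Compound 1 `CCOC(=O)CN(C(=O)/C(C)=C/c1ccc(C(=O)Oc2ccc(C(=N)N)cc2)cc1)C1CCCCC1` likewise gives > 1 h in this assay, again a limit. Compound 2 `C/C(=C\c1ccc(C(=O)Oc2ccc(C(=N)N)cc2)cc1)C(=O)N(CC(=O)O)Cc1ccccc1` gives 0.833 h in this assay. For the measured compounds named here, the only step between neighbours, an at least 1.2-fold higher number from compound 2 to compound 3 (0.07 log units; that floor lies within the scatter), lies within the scatter, and the limit of > 1 h in this assay, at which 2 of the 3 values shown sit, shows that most values reach the limit. Compound 4 `C=CCN(CCC(=O)O)C(=O)/C(C)=C/c1ccc(C(=O)Oc2ccc(C(=N)N)cc2)cc1` carries allyl(2-carboxyethyl)amino in place of (carboxymethyl)(ethyl)amino on a carbonyl carbon. Going by the values given here, no measured step touches this change, so no shift beyond the scatter is expected. Compound 4 is therefore expected to give 1.2 h in this assay, between 0.6 h and 2.5 h. The expected step is a step that the limit leaves unreadable from compound 3 to compound 4.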

Compound 4, half-life: > 1 h
Compound 4 gave a limit, no number (the forecaster's own chance of this, stated with the estimate: 55%); the middle value lies beyond the limit too.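

No step from compound 3 to compound 4 can be read in this assay, as both results are limits and not numbers: the limit of > 1 h in this assay, at which 3 of the 4 values shown sit.

The compounds shown leave open whether allyl(2-carboxyethyl)amino in place of (carboxymethyl)(ethyl)amino changes the half-life at all.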